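The source may report more compounds than this note shows. Statements on the series, on what has been measured and on what is new or still open speak of the compounds shown alone.

Compound 1, `Cc1cc(C)cc(S(=O)(=O)c2c(C(=O)NC(c3ccc(Cl)cc3)C3CC3)[nH]c3ccc(Cl)cc23)c1`: in an ADME assay on MT4 cells (Homo sapiens) for cytotoxicity, read by MTT assay (on this read-out lower numbers stand for higher toxicity in this test and higher numbers for lower toxicity in this test), compound 1 gives > 47300 nM, which is a limit of the assay.
Compound 2, `Cc1cc(C)cc(S(=O)(=O)c2c(C(=O)NCC(=O)NCc3ccco3)[nH]c3ccc(Cl)cc23)c1`: in this assay compound 2 gives > 50000 nM, again a limit of the assay.
Compound 3, `Cc1cc(C)cc(S(=O)(=O)c2c(C(=O)NCC(=O)NCCn3c(C)cnc3[N+](=O)[O-])[nH]c3ccc(Cl)cc23)c1`: in this assay compound 3 gives 24500 nM.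

Compound 2 therefore stands at a limit of this assay, with no number of its own, and one of the two other values shown is a limit as well. Compound 4, `Cc1cc(C)cc(S(=O)(=O)c2c(C(=O)NC(C)c3cc(F)cc(F)c3)[nH]c3ccc(Cl)cc23)c1`, differs from compound 2 by 1-(3,5-difluorophenyl)ethyl in place of (((furan-2-yl)methyl)carbamoyl)methyl on an amide-type nitrogen. Going by the values given here, two measured steps touch the series: a step that the two limits leave unreadable from compound 1 to compound 2, which the two limits (the limit of > 47300 nM in this assay, at which 1 of the 3 values shown sits, (the limit of > 50000 nM in this assay, at which 1 of the 3 values shown sits)) leave unreadable, and an at least 2.0-fold lower number from compound 2 to compound 3 (0.30 log units; that floor lies within the scatter). Neither involves the group entering in compound 4, and the measured compounds give no reading of its effect. Compound 1, whose group on the same amide-type nitrogen is nearer in kind to that of compound 4, also sits at a limit. Compound 4 is thus expected to stay near the limit of this assay, at about 50000 nM with a range from 20000 nM to 100000 nM. The expected step is a number no higher from compound 2 to compound 4 (the limit leaves the size open), nothing beyond the scatter.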

Compound 4, half-maximal cytotoxic concentration: > 49700 nM
Compound 4: only a limit was reported (the forecaster's own chance of this, stated with the estimate: 65%); the middle value is on the limit's open side.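

In this assay compound 4 gives > 49700 nM, which is a limit of the assay. Compound 1 and compound 2 also stand at limits, and the steps from each of them to compound 4 cannot be read. The compounds shown leave open whether 1-(3,5-difluorophenyl)ethyl on the amide-type nitrogen changes the read-out at all.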